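A few compounds are considered here, and "the series" means these few. Any claim that something is new, unique, unknown or untested is made for them only; others in the source may bear on it.

Of the compounds shown here, three with a shared core have been tested in a functional assay on Huh-5-2 cells (Homo sapiens), read by MTT assay; a lower number here means that less compound is tolerated, a higher number that more compound is tolerated. Compound 1 (`O=C(O)c1ccc(-c2ccc(Cl)cc2COc2ccc(-c3nc4cc(C(=O)O)ccc4n3C3CCCCC3)cc2)cc1`) reports > 50000 nM, which is a limit of the assay and not a number. Compound 2 (`COc1ccc(-c2ccc(Cl)cc2)c(COc2ccc(-c3nc4cc(C(=O)O)ccc4n3C3CCCCC3)cc2)c1`) gives 24000 nM, and compound 3 (`CN(C)c1ccc(-c2ccc(Cl)cc2)c(COc2ccc(-c3nc4cc(C(=O)O)ccc4n3C3CCCCC3)cc2)c1`) gives 30000 nM. Compound 2 therefore has just one true number to be compared with, and the two stand level, as the step shows: a 1.3-fold higher number from compound 2 to compound 3 (0.10 log units; within the scatter). That step puts dimethylamino in place of methoxy on an aromatic carbon.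

Compound 4 (`CN(C)C(=O)c1ccc(-c2ccc(Cl)cc2)c(COc2ccc(-c3nc4cc(C(=O)O)ccc4n3C3CCCCC3)cc2)c1`) changes the same group of compound 2, with dimethylcarbamoyl in place of methoxy on an aromatic carbon, meta to a large group and para to a 4-chlorophenyl group: dimethylcarbamoyl in place of methoxy on an aromatic carbon. For the measured compounds named here, the swap from compound 2 to compound 3 is the only measured step that bears on this one. Its size, a 1.3-fold higher number from compound 2 to compound 3 (0.10 log units; within the scatter), gives no reason to expect a move beyond the scatter in this assay, though one step is thin support. The expected change is a 1.2-fold higher number from compound 2 to compound 4 (0.07 log units; within the scatter). For compound 4 the estimated value is 28000 nM, with an expected range of 13000 nM to 50000 nM.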

Compound 4, half-maximal cytotoxic concentration: 28000 nM
The estimate for compound 4 equals the measured number at the digits printed, within the range that was stated.
By their numbers in this assay, from the lowest: compounds 2, 4 and 3 (each within the scatter of the next). At a limit, above all of these: compound 1.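

Dimethylcarbamoyl is a larger group than methoxy, with five heavy atoms against two and a double bond outside the aromatic ring, yet the swap gives a 1.2-fold higher number from compound 2 to compound 4 (0.07 log units; within the scatter). Set against dimethylamino, the same group gives a 1.1-fold lower number from compound 3 to compound 4 (0.03 log units; within the scatter). For the compounds shown here, at this position, para to a 4-chlorophenyl group, the comparison now covers three different groups that stand level, where the earlier compounds offered only two.

From the compounds shown here alone, whether a primary amine or a longer alkyl chain at this position would move the number beyond the scatter stays open. Compound 1 gives only a limit of the assay and not a number, so how far it lies from the other compounds also stays open: the limit of > 50000 nM in this assay, at which 1 of the 4 values shown sits.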